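Biaryl amide acids: cytotoxicity check at the aryl end

This account rests on a few compounds, and the source may have more. Where it says the series, first, only, none or still open, it means among the compounds named here.

Compound 1 `CC(C)N(Cc1cccc(OCCCCCC(=O)O)c1)C(=O)c1ccc(-c2ccsc2)cc1`: in an ADME assay on HepG2 cells (Homo sapiens) for cytotoxicity, read by CellTiter-Glo and resazurin assay, with a stated time of 72 h (on this read-out lower numbers stand for an effect already at smaller amounts and higher numbers for an effect only at larger amounts of compound), compound 1 gives > 26000 nM, a limit of the assay.
Compound 2 `CC(C)N(Cc1cccc(OCCCCCC(=O)O)c1)C(=O)c1ccc(-c2cccc(O)c2)cc1`: in this assay compound 2 gives > 26000 nM, again a limit.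
Compound 3 `CC(C)N(Cc1cccc(OCCCCCC(=O)O)c1)C(=O)c1ccc(-c2c[nH]c3ccccc23)cc1`: in this assay compound 3 gives > 26000 nM, also a limit.

Compound 3 stands only at a limit, and the two other values in the series are limits as well, so all three compounds sit at the same ceiling (the limit of > 26000 nM in this assay, at which 3 of the 3 values shown sit). The steps a step that the two limits leave unreadable from compound 1 to compound 2, a step that the two limits leave unreadable from compound 1 to compound 3 and a step that the two limits leave unreadable from compound 2 to compound 3 are accordingly of unreadable size.

Compound 4 `COc1ccc(F)c(-c2ccc(C(=O)N(Cc3cccc(OCCCCCC(=O)O)c3)C(C)C)cc2)c1` is to be measured; it differs from compound 3 by 2-fluoro-5-methoxyphenyl in place of 1H-indol-3-yl on an aromatic carbon. Among the compounds with values here, no measured step reports a readable size for such an exchange; what the series shows is that three different aryl groups at this position all leave the read-out at the limit (the limit of > 26000 nM in this assay, at which 3 of the 3 values shown sit). The expectation is therefore no step beyond the scatter, a step that the limit leaves unreadable from compound 3 to compound 4, with compound 4 most likely reported as a limit as well. Compound 4 is estimated at 35000 nM in this assay, with a range of 15000 nM to 120000 nM.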

Compound 4, half-maximal effective concentration: > 26000 nM
Compound 4: no number, only a limit (the forecaster's own chance of this, stated with the estimate: 85%); the middle value is on the limit's open side.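

Compound 4, like compound 1, compound 2 and compound 3, gives only a limit in this assay, so none of its steps to those compounds can be read: the limit of > 26000 nM in this assay, at which 4 of the 4 values shown sit.

The compounds shown leave open whether any aryl group at this position reaches a measurable effect, and how far these four compounds differ.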